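A Methylsulfanyl-to-Amino Swap on a Bicyclic Core

The source may report more compounds than this note shows. Statements on the series, on what has been measured and on what is new or still open speak of the compounds shown alone.

Compound 1 `CSc1[nH]ccc2ncnc1-2` is the smallest member of this set, a bare bicyclic core without a sugar. In a functional assay (Homo sapiens) for inhibition of Nucleic Acid, tested at 100 uM (on this read-out lower numbers stand for less inhibition and higher numbers for more inhibition at the one concentration tested (going by the name of the read-out)), compound 1 gives 4%, the lowest of the three numbers recorded. Compound 2 `[N-]=[N+]=Nc1nccc2ncn([C@H]3C[C@H](O)[C@@H](CO)O3)c12` in this assay gives 14%, a number that sits within the usual scatter of the reading for compound 1, while compound 3 `OC[C@H]1O[C@@H](n2cnc3c(SCc4ccccc4)nccc32)C[C@@H]1O` in this assay gives 18%, which lies beyond that scatter. For the measured compounds named here, no pair of these three compounds differs in a single place, so no step between measured compounds can be read off.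

Compound 4 `Nc1[nH]ccc2ncnc1-2` is the untested analogue of compound 1, and the change between them is amino in place of methylsulfanyl on an aromatic carbon. Going by the values given here, nothing among the measured compounds shows what such a swap does in this assay. Compound 4 is therefore expected to stay close to its parent, with a step of a number 4 percentage points higher from compound 1 to compound 4 (within the scatter) that is not expected to exceed the scatter. The estimate for compound 4 in this assay is 8%, with a range from 0% to 22%.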

Compound 4, a percentage reported as inhibition, at one concentration (the size of the read-out at that concentration, not a potency): 60%
Compound 4: the middle estimate sits 52 percentage points below what was measured; the whole stated range lies below it.
By their numbers in this assay, from the lowest: compounds 1, 2 and 3 (each within the scatter of the next, the first and the last beyond it); then compound 4.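

Placing amino in place of methylsulfanyl on an aromatic carbon next to the ring nitrogen gives a step of a number 56 percentage points higher from compound 1 to compound 4 (beyond the scatter) in this assay, so the read-out is sensitive to the group at this place on the core. For the compounds shown here, the earlier compounds offered no comparison in one place, and this is the first step that ties a change in the read-out to a single group, on a core without a sugar. Nothing measured here explains the size of this step.

It remains open whether the read-out follows amino itself or the departure of methylsulfanyl: the compounds shown hold no methylamino, dimethylamino or hydroxyl group at this place. Also open, as far as these compounds go, is whether amino has a similar effect on a core that carries a sugar.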